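Moving a Hydroxyl Group on Two Related Cores

The source may hold more compounds than are shown below. What is called first, only, known or untested is meant among the compounds shown, and "the series" means these compounds.

Three compounds have been measured in a functional assay on HL-60 cells (Homo sapiens) for cytotoxicity, read by ELISA, with a stated time of 2 days; a lower number here means a stronger inhibitor, a higher number a weaker inhibitor:
compound 1 `Oc1cccc(-c2cc(-c3ccccc3)cc(-c3ccccc3)n2)c1` gives 11500 nM;
compound 2 `Oc1ccc(-c2cc(-c3ccccc3)cc(-c3ccccc3)n2)cc1` gives 1400 nM;
compound 3 `Oc1cccc(-c2cc(-c3ccccc3)nc(-c3ccco3)c2)c1` gives 24000 nM.

Compound 1 and compound 2 share one core and differ only by 4-hydroxyphenyl in place of 3-hydroxyphenyl on an aromatic carbon, a change that gave an 8.2-fold lower number from compound 1 to compound 2 (0.91 log units; beyond the scatter). Compound 3 carries a different core; how the two cores differ is not broken down here. Compound 4 `Oc1ccc(-c2cc(-c3ccccc3)nc(-c3ccco3)c2)cc1` has not been measured yet and differs from compound 3 by 4-hydroxyphenyl in place of 3-hydroxyphenyl on an aromatic carbon. This is the same kind of change, not the same one: in compound 1 the changed group sits next to the ring nitrogen and meta to two phenyl groups, whereas in compound 3 it sits meta to a furan-2-yl group, meta to a phenyl group, and opposite the ring nitrogen. Because the step from compound 1 to compound 2 was an 8.2-fold lower number from compound 1 to compound 2 (0.91 log units; beyond the scatter), a step of similar size is expected in this assay, namely a 6.0-fold lower number from compound 3 to compound 4 (0.78 log units; beyond the scatter), though the different surroundings make this less certain. Compound 4 is therefore estimated at 4000 nM, expected to lie between 1500 nM and 12000 nM.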

Compound 4, half-maximal inhibitory concentration: 13700 nM
Estimate against measurement, compound 4: 3.4-fold (0.53 log units) below; the whole stated range lies below it.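

Moving the hydroxyl from 3-hydroxyphenyl to 4-hydroxyphenyl gave, in this assay, a 1.8-fold lower number from compound 3 to compound 4 (0.24 log units; within the scatter), so on this core the step cannot be told apart from the ordinary spread of repeated measurements. The size of the step did not carry over from one core to the other: the same change on two cores in this assay, an 8.2-fold lower number (0.91 log units; beyond the scatter) from compound 1 to compound 2 and a 1.8-fold lower number (0.24 log units; within the scatter) from compound 3 to compound 4, 4.7-fold (0.67 log units) apart, beyond the scatter of two such steps. Two pairs do not show which difference between the cores matters, or what size the step would take on a further core.

Still open, on these data alone, is how the two cores would compare with an amine or a carboxylic acid in place of the hydroxyl. Also open, as far as these compounds go, is whether the furan-2-yl group itself has any part in the smaller step.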